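The source may report more compounds than this note shows. Statements on the series, on what has been measured and on what is new or still open speak of the compounds shown alone.

Measured so far in an ADME assay on the whole organism (strain FVB) for pharmacokinetics, with Mus musculus as the target, read by LC-MS, at a dose of 30 mg/kg by the oral route; a lower number here means less compound in the circulation, a higher number more compound in the circulation at the dose given:
Compound 1, `CC(C)(O)CN1CCC(Oc2ccc([C@H]3CC[C@]4(CC3)OOC3(O4)C4CC5CC(C4)CC3C5)cc2)CC1`, gives 14200 ng.h/mL.
Compound 2, `c1cc([C@H]2CC[C@]3(CC2)OOC2(O3)C3CC4CC(C3)CC2C4)ccc1OCC1CCNCC1`, gives 4040 ng.h/mL.
Compound 3, `c1cc([C@H]2CC[C@]3(CC2)OOC2(O3)C3CC4CC(C3)CC2C4)ccc1OCCC1CCNCC1`, gives 16000 ng.h/mL.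

Compound 3 and compound 1 lie within the usual scatter of each other, as a 1.1-fold higher number from compound 1 to compound 3 (0.05 log units; within the scatter) shows; compound 3 stands clearly above compound 2 only, a 4.0-fold higher number from compound 2 to compound 3 (0.60 log units; beyond the scatter). Compound 4, `CC(C)(CN)Oc1ccc([C@H]2CC[C@]3(CC2)OOC2(O3)C3CC4CC(C3)CC2C4)cc1`, is not yet measured. It differs from compound 3 by 1-(aminomethyl)-1-methylethyl in place of 2-(piperidin-4-yl)ethyl on an oxygen on an aromatic ring. Within the data shown here, no measured step exchanges the ring for an open chain in this way, so the known steps bear only loosely: a 3.5-fold lower number from compound 1 to compound 2 (0.55 log units; beyond the scatter) and a 4.0-fold higher number from compound 2 to compound 3 (0.60 log units; beyond the scatter) show that changing the group on this oxygen moves the number modestly in either direction. A modest fall is therefore expected, a 2.0-fold lower number from compound 3 to compound 4 (0.30 log units; within the scatter). Compound 4 is estimated at 8000 ng.h/mL. Its range is expected to run from 3000 ng.h/mL to 22000 ng.h/mL.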

Compound 4, area under the concentration-time curve: 4840 ng.h/mL
The estimate for compound 4 lay 1.7-fold (0.22 log units) above the measured number; the range from low to high includes it.
By their numbers in this assay, from the lowest: compounds 2 and 4 (each within the scatter of the next); then compounds 1 and 3 (each within the scatter of the next).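

Swapping the ring-bearing groups on this oxygen for the open-chain 1-(aminomethyl)-1-methylethyl does not give a single outcome in this assay. The number falls against the two heavier-scoring ring compounds (a 3.3-fold lower number from compound 3 to compound 4 (0.52 log units; beyond the scatter)) and (a 2.9-fold lower number from compound 1 to compound 4 (0.47 log units; beyond the scatter)), yet stays within the scatter of the ring-bearing (piperidin-4-yl)methyl group (a 1.2-fold higher number from compound 2 to compound 4 (0.08 log units; within the scatter)). Losing the ring therefore does not by itself set the number here. No measurement shown explains these differences. Open, on these data alone, is how this oxygen would fare carrying a carboxylic acid, with no amine in the group.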